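A Larger Ether Group on an Aromatic Oxygen

The source may report more compounds than this note shows. Statements on the series, on what has been measured and on what is new or still open speak of the compounds shown alone.

Compound 3 `O=c1c(-c2ccc(F)cc2)c[nH]c2ccnc(Nc3ccc(Oc4ccnc5cc(O)ccc45)c(F)c3)c12` is one of three close relatives tested in a functional assay on HT-29 cells (Homo sapiens) for antiproliferative activity, read by MTT assay, with a stated time of 72 h; on this read-out lower numbers stand for stronger inhibition and higher numbers for weaker inhibition. Compound 3 gives 5900 nM. Compound 1 `COCCOc1ccc2c(Oc3ccc(Nc4nccc5[nH]cc(-c6ccc(F)cc6)c(=O)c45)cc3F)ccnc2c1` gives 6500 nM, and compound 2 `COCCOc1cc2nccc(Oc3ccc(Nc4nccc5[nH]cc(-c6ccc(F)cc6)c(=O)c45)cc3F)c2cc1OC` gives 4600 nM. Compound 3 stands second highest of the three, though all three lie within the usual scatter of one another. Compound 4 `COC(C)(C)COc1ccc2c(Oc3ccc(Nc4nccc5[nH]cc(-c6ccc(F)cc6)c(=O)c45)cc3F)ccnc2c1` differs from compound 3 by 2-methoxy-2-methylpropyl in place of hydrogen on an oxygen on an aromatic ring. The step that bears on this is a 1.1-fold lower number from compound 1 to compound 3 (0.04 log units; within the scatter), in which hydrogen in place of 2-methoxyethyl on an oxygen on an aromatic ring left the number within the scatter; the step of a 1.4-fold lower number from compound 1 to compound 2 (0.15 log units; within the scatter) was likewise flat. A larger ether group at that oxygen is therefore expected to give compound 4 a step of a 1.1-fold lower number from compound 3 to compound 4 (0.03 log units; within the scatter). Compound 4 is estimated at 5500 nM, with a range from 2500 nM to 12000 nM.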

Compound 4, half-maximal inhibitory concentration: 4800 nM
Estimate against measurement, compound 4: 1.1-fold (0.06 log units) above, within the range that was stated.
By their numbers in this assay, from the lowest: compounds 2, 4, 3 and 1 (each within the scatter of the next).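

Putting 2-methoxy-2-methylpropyl in place of hydrogen on the oxygen gives a 1.2-fold lower number from compound 3 to compound 4 (0.09 log units; within the scatter), so even a chain of 6 heavy atoms there leaves the number within the scatter. Changing the chain itself, with 1-methoxy-1-methylethyl in place of methoxymethyl, gives a 1.4-fold lower number from compound 1 to compound 4 (0.13 log units; within the scatter), which shows that the flat picture also holds for this branched ether. No measurement at hand offers a reason for this flatness. Every group shown on this oxygen is hydrogen or an ether, so it remains open whether a chain carrying an amine or a carboxylic acid would move the number beyond the scatter.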